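This account rests on a few compounds, and the source may have more. Where it says the series, first, only, none or still open, it means among the compounds named here.

Values in a functional assay on HeLa cells (Homo sapiens) for antiproliferative activity, read by CCK-8 assay, with a stated time of 72 h, tested at 2 uM (a higher number here means a stronger effect of the compound at the concentration tested, a lower number a weaker effect), at the single concentration used:

compound 1, `Nc1ccccc1NC(=O)c1ccc(CSC(=S)N2CCN(C3CCCCC3)CC2)cc1`: 30.6%
compound 2, `Nc1ccccc1NC(=O)c1ccc(CSC(=S)N2CCc3ccc([N+](=O)[O-])cc32)cc1`: 45.7%
compound 3, `CC1CCN(C(=S)SCc2ccc(C(=O)Nc3ccccc3N)cc2)CC1`: 46.8%

Compound 1 stands lowest of the three numbers. Compound 2 lies above it by a margin beyond the usual scatter, and compound 3, the furthest from compound 1, lies above it by a slightly larger margin, also beyond the scatter. Among the compounds with values here, the three compounds share the core of compound 1 and differ in the group carried on the thiocarbamoyl nitrogen; none of them differs from another in a single place, so no measured step isolates one change.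

Compound 4, `Nc1ccccc1NC(=O)c1ccc(CSC(=S)N2CCN(c3ccccc3)CC2)cc1`, has not yet been measured in this assay. Relative to compound 1 the change is phenyl in place of cyclohexyl on an amine nitrogen in a ring. The place of the change is the same in both, so the core and its link to the rest remain untouched.

Within the data shown here, with no measured pair to calibrate this change, the step from compound 1 to compound 4 is expected to be small and upward, probably within the usual scatter or only just beyond it. The expected step is a number 7.4 percentage points higher from compound 1 to compound 4 (within the scatter). Compound 4 is accordingly estimated at 38%, with a range from 25% to 52%.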

Compound 4, a percentage reported as inhibition, at one concentration (the size of the read-out at that concentration, not a potency): 62.2%
Compound 4: the middle estimate sits 24.2 percentage points below what was measured, outside the stated range (above it).
By their numbers in this assay, from the lowest: compound 1; then compounds 2 and 3 (each within the scatter of the next); then compound 4.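

In this assay, within the data shown here, the change of cyclohexyl to phenyl on an amine nitrogen in a ring gives the first step that isolates one change: a number 31.6 percentage points higher from compound 1 to compound 4 (beyond the scatter), with the shared core left untouched. Both groups have 6 heavy atoms, 0 hydrogen-bond donors and 0 hydrogen-bond acceptors, so this position responds strongly to a swap of a non-aromatic ring of carbon for an aromatic one even though those counts stay the same. The data on hand offer nothing that accounts for the size of this step.

On these data alone, it remains open whether the higher number in this assay is specific to phenyl or would also appear with a pyridyl ring, a benzyl group or a methoxy-substituted phenyl on the same nitrogen. As far as these compounds go, it is also open whether the step would keep its size at other concentrations, as a reading at a single concentration is not a potency.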